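The source may report more compounds than this note shows. Statements on the series, on what has been measured and on what is new or still open speak of the compounds shown alone.

Measured so far:
Compound 1 `COc1cc(-c2ccnc3cc(-c4ccc(C(C)(C)C)cc4)nn23)cc(OC)c1OC` gives > 10000 nM in a functional assay on MCF7 cells (Homo sapiens) for inhibition, read by CCK-8 assay, with a stated time of 48 h (a higher number here means a weaker inhibitor, a lower number a stronger inhibitor), which is a limit of the assay and not a number.
Compound 2 `COc1cc(-c2ccnc3cc(-c4ccc(C(C)=O)cc4)nn23)cc(OC)c1OC` gives 5230 nM in this assay.

Compound 2 is thus the only one of the two with a real number; the other value is a limit. Among the measured compounds shown here, the step of an at least 1.9-fold lower number from compound 1 to compound 2 (0.28 log units; that floor lies within the scatter) is the one measured change, and it exchanged one group for another on an aromatic carbon; its floor rests on (the limit of > 10000 nM in this assay, at which 1 of the 2 values shown sits).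

Compound 3 `COc1cc(-c2ccnc3cc(-c4ccccc4)nn23)cc(OC)c1OC` is not yet measured. It differs from compound 2 as follows: hydrogen in place of acetyl on an aromatic carbon. The measured step swapped acetyl for tert-butyl, whereas here the acetyl is removed altogether and only hydrogen remains, so that step gives only an indirect guide. Compound 2 does not stand far from the limit, so a shift toward a higher number could leave compound 3 at a limit as well. A modest step toward a higher number, or none beyond the scatter, is expected: a 1.5-fold higher number from compound 2 to compound 3 (0.18 log units; within the scatter). Compound 3 is estimated at 8000 nM, in the range 3000 nM to 25000 nM.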

Compound 3, half-maximal inhibitory concentration: 254 nM
Compound 3: middle estimate off by 31-fold (1.50 log units), on the high side, and the stated range ends above it.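

Hydrogen in place of acetyl on this aromatic carbon, para to a large group, gives a 21-fold lower number from compound 2 to compound 3 (1.31 log units; beyond the scatter) in this assay, which shows that this position needs neither of the two groups for activity against these cells. Hydrogen in place of tert-butyl gives an at least 39-fold lower number from compound 1 to compound 3 (1.59 log units; beyond the scatter); compound 1 stands at a limit of the assay, so this size is only a floor: the limit of > 10000 nM in this assay, at which 1 of the 3 values shown sits. The earlier step compared two substituted rings and could not show this, whereas the unsubstituted phenyl of compound 3 now reveals that, among these three compounds, having either group at this position carries a large cost, even though acetyl and tert-butyl are very different groups.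

What the compounds shown leave open is whether every group at this position costs as much, or only groups as large as these two, and a single fluorine atom or a methyl group would begin to separate those cases. An amine or a carboxylic acid in the same place would show whether the cost also holds for groups of quite another kind.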